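A few compounds are considered here, and "the series" means these few. Any claim that something is new, unique, unknown or untested is made for them only; others in the source may bear on it.

Measured in a functional assay on DU-145 cells (Homo sapiens) for inhibition, read by trypan blue exclusion, with a stated time of 96 h; a lower number here means a stronger inhibitor of growth, a higher number a weaker inhibitor of growth:
compound 1, `COc1ccc(/C=C(/Sc2ccc(Br)cc2)C(=O)c2ccc(Br)cc2)cc1`: 25000 nM.
compound 2, `Cc1ccc(S/C(=C/c2c(O)cc(O)cc2O)C(=O)c2ccc(Br)cc2)cc1`: the value of compound 2 is a limit of this assay, > 100000 nM.
compound 3, `Cc1ccc(S/C(=C/c2ccc(N(C)C)cc2)C(=O)c2ccc(Br)cc2)cc1`: the value of compound 3 is a limit of this assay, > 100000 nM.

Compound 3 stands only at a limit in this assay, so no number is known for it. For the measured compounds named here, the one measured step that leads to it, a step that the two limits leave unreadable from compound 2 to compound 3, cannot be read because both of its ends sit at the limit of > 100000 nM in this assay, at which 2 of the 3 values shown sit.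

Compound 4, `COc1ccc(/C=C(/Sc2ccc(C)cc2)C(=O)c2ccc(Br)cc2)cc1`, differs from compound 3 by methoxy in place of dimethylamino on an aromatic carbon. Going by the values given here, no measured step in this set makes this same change, and the single step measured, from compound 2 to compound 3, is unreadable and says nothing about its size or direction. Among the compounds with values here, the only other number in this assay comes from compound 1, which carries the same 4-methoxyphenyl group as compound 4 and gives a value rather than a limit; no step between compound 1 and compound 4 is computed here, so it serves only as a reference point.

For compound 4 a number rather than a limit is expected, with an estimate of 40000 nM, in the range 15000 nM to 120000 nM. That estimate means a step of an at least 2.5-fold lower number from compound 3 to compound 4 (0.39 log units; beyond the scatter), toward stronger inhibition of growth, though against a limit its true size stays unreadable.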

Compound 4, concentration for 50% growth inhibition: 50000 nM
For compound 4 the middle estimate is 1.3-fold (0.10 log units) below the measured one; measured number inside the range.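

In this assay, methoxy in place of dimethylamino on an aromatic carbon, para to a large group, replaces a limit with a number, and the step reads an at least 2.0-fold lower number from compound 3 to compound 4 (0.30 log units; that floor lies within the scatter). The 4-methoxyphenyl group set against the 2,4,6-trihydroxyphenyl group gives an at least 2.0-fold lower number from compound 2 to compound 4 (0.30 log units; that floor lies within the scatter), and both of these sizes remain floors because one end of each step sits at a limit: the limit of > 100000 nM in this assay, at which 2 of the 4 values shown sit. Methyl in place of bromo on an aromatic carbon gives a 2.0-fold higher number from compound 1 to compound 4 (0.30 log units; within the scatter), the first step in the series with a number at both ends, so with the 4-methoxyphenyl group kept, this exchange does not separate the two compounds in this assay.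

Open, on these data alone, is the true size of the steps that start from a limit, and whether an ethoxy group or a primary amine on the methoxy-bearing carbon would give a number of similar size. Also open, as far as these compounds go, is whether a chloro or a trifluoromethyl group, in the place that holds methyl or bromo, would keep the number within the same range.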